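The source may hold more compounds than are shown below. What is called first, only, known or untested is meant among the compounds shown, and "the series" means these compounds.

Among the measured compounds shown here, in a functional assay on HCT-116 cells (Homo sapiens) for inhibition, with a stated time of 72 h (on this read-out lower numbers stand for stronger inhibition and higher numbers for weaker inhibition), compound 1 (`O=S(=O)(Nc1cccc2c(Cl)c[nH]c12)c1cccnc1`) gives 260 nM, and compound 2 (`CC(C)Nc1ccc(S(=O)(=O)Nc2cccc3c(Cl)c[nH]c23)cn1`) gives 1300 nM, the higher of the two numbers so far. Compound 3 (`O=S(=O)(Nc1cccc2c(Cl)c[nH]c12)c1ccc(NCCO)nc1`) differs from compound 2 in one place: 2-hydroxyethyl in place of isopropyl on a nitrogen on an aromatic ring. Put simply, this is 2-hydroxyethyl in place of isopropyl on a nitrogen on an aromatic ring. For the measured compounds named here, no measured step makes this exact swap, so the evidence is indirect. Going by the values given here, the only step that bears on it is a 5.0-fold higher number from compound 1 to compound 2 (0.70 log units; beyond the scatter), which came with isopropylamino in place of hydrogen on an aromatic carbon. Compound 3 keeps that nitrogen and changes only the group on it, so a step smaller than that modest one is expected, leaning toward a lower number. The expected change is a 1.4-fold lower number from compound 2 to compound 3 (0.16 log units; within the scatter), which is only an estimate. For compound 3, the estimated value is 900 nM, with an expected range of 300 nM to 2700 nM.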

Compound 3, half-maximal inhibitory concentration: 650 nM
Compound 3: middle estimate off by 1.4-fold (0.14 log units), on the high side; low and high end bracket the measured number.
By their numbers in this assay, from the lowest: compound 1; then compounds 3 and 2 (each within the scatter of the next).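

Swapping isopropyl for 2-hydroxyethyl on the nitrogen gives a 2.0-fold lower number from compound 2 to compound 3 (0.30 log units; within the scatter), so this assay does not separate compound 2 from compound 3, even though the entering group carries a hydrogen-bond donor and a hydrogen-bond acceptor that isopropyl lacks. Set against the plain hydrogen of compound 1, the (2-hydroxyethyl)amino group gives a 2.5-fold higher number from compound 1 to compound 3 (0.40 log units; beyond the scatter), so both substituted amino groups shown now stand beyond the scatter from compound 1, and neither compound goes against this. No measurement shown here offers an explanation for these numbers.

The compounds shown leave open how a bare amino group, or a longer chain ending in a hydroxyl on that nitrogen, would read in this assay. They also leave open whether a group joined through something other than nitrogen, such as a methoxy group or a carboxylic acid, would come closer to compound 1.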